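Swapping a Fluorine for Chlorine on a Fused Ring

A few compounds are considered here, and "the series" means these few. Any claim that something is new, unique, unknown or untested is made for them only; others in the source may bear on it.

Compound 1, `O=C(Nc1nc2ccc(Cl)cc2s1)c1cn(-c2ccccc2)nc1-c1ccc(F)cc1`: 3320 nM
Compound 2, `O=C(Nc1nc2ccc(F)cc2s1)c1cn(-c2ccccc2)nc1-c1ccc(Cl)cc1`: 4970 nM

Both compounds were tested in a functional assay on HT-29 cells (Homo sapiens) for cytotoxicity, read by MTT assay, with a stated time of 72 h; a higher number here means a weaker inhibitor, a lower number a stronger inhibitor. Among the compounds with values here, compound 2 stands at the higher of the two numbers measured so far, and its nearest neighbour is compound 1, which gives 3320 nM; the gap between them lies within the scatter, so the two cannot be ordered with confidence. Compound 3, `O=C(Nc1nc2ccc(Cl)cc2s1)c1cn(-c2ccccc2)nc1-c1ccc(Cl)cc1`, has not yet been measured in this assay. It differs from compound 2 in a single place: chloro in place of fluoro on an aromatic carbon. Within the data shown here, no step between two measured compounds shows this exact change, so nothing in the data fixes its direction. Compound 1 carries chloro at the same place of the fused ring and gives 3320 nM, a number close to that of compound 2. For compound 3 the expectation is therefore a step of a 1.4-fold lower number from compound 2 to compound 3 (0.14 log units; within the scatter), small and within the scatter, with no clear direction. Compound 3 is estimated at 3600 nM in this assay, with a range from 1500 nM to 8500 nM.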

Compound 3, half-maximal inhibitory concentration: 4550 nM
Beside the measured number, compound 3's estimate is 1.3-fold (0.10 log units) below it, within the range that was stated.
By their numbers in this assay, from the lowest: compounds 1, 3 and 2 (each within the scatter of the next).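

In this assay, the change from 6-fluoro-1,3-benzothiazol-2-yl to 6-chloro-1,3-benzothiazol-2-yl can now be read directly (a 1.1-fold lower number from compound 2 to compound 3 (0.04 log units; within the scatter)), and on this fused ring the exchange of one halogen for the other leaves the number within the scatter. Compound 3 also gives a second reading of the same exchange at a different aromatic carbon, outside the fused ring (a 1.4-fold higher number from compound 1 to compound 3 (0.14 log units; within the scatter)), so at both places fluoro and chloro cannot be told apart in this assay, although each step rests on a single pair of compounds. Nothing measured here offers an explanation for these small steps.

The compounds shown carry only fluoro or chloro at these two places, so they do not show whether this position responds to anything other than a halogen. An amine, a carboxylic acid or a longer chain such as a propyl group on the fused ring could move the number beyond the scatter, or could leave it just as unchanged.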